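Swapping Methoxy for Methyl in Compound 3

A few compounds are considered here, and "the series" means these few. Any claim that something is new, unique, unknown or untested is made for them only; others in the source may bear on it.

In a functional assay on CHP-134 cells (Homo sapiens) for antiproliferative activity, with a stated time of 72 h (a higher number here means a weaker inhibitor, a lower number a stronger inhibitor), compound 1 `O=C(CCN(Cc1ccc(C(=O)NO)cc1)C(=O)c1ccccc1)NCc1ccccc1` gives 4680 nM and compound 2 `COc1ccc(C(=O)N(CCC(=O)NCc2ccccc2)Cc2ccc(C(=O)NO)cc2)cc1` gives 1900 nM, the lower of the two numbers. Compound 3 `Cc1ccc(C(=O)N(CCC(=O)NCc2ccccc2)Cc2ccc(C(=O)NO)cc2)cc1` has methyl in place of methoxy on an aromatic carbon, para to a large group: methyl in place of methoxy on an aromatic carbon. Going by the values given here, the one measured step that bears on this change is modest: a 2.5-fold lower number from compound 1 to compound 2 (0.39 log units; beyond the scatter), with methoxy in place of hydrogen. Among the compounds with values here, with only that step as a guide, a modest move to a higher number is expected in this assay, an estimated 1.4-fold higher number from compound 2 to compound 3 (0.14 log units; within the scatter). Compound 3 is expected to give 2600 nM, with an estimated range of 1200 nM to 5500 nM.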

Compound 3, half-maximal inhibitory concentration: 1100 nM
For compound 3 the middle estimate is 2.4-fold (0.37 log units) above the measured one; the measured number lies below the stated range.
By their numbers in this assay, from the lowest: compounds 3 and 2 (each within the scatter of the next); then compound 1.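

In this assay, methoxy and methyl at this position cannot be told apart, since a 1.7-fold lower number from compound 2 to compound 3 (0.24 log units; within the scatter) stays inside the usual scatter. Methyl, the smaller of the two groups, still does better than hydrogen, with a 4.3-fold lower number from compound 1 to compound 3 (0.63 log units; beyond the scatter) lying beyond the scatter, so the step from hydrogen does not depend on the oxygen of methoxy. No measured evidence here explains why either group behaves as it does.

From the compounds shown here alone, it remains open how a chlorine atom, an amine or a carboxylic acid would fare at this position. Whether a longer chain such as ethyl or propyl would keep the number this low is also unanswered.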